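Indanyl in place of acetamidophenylethyl on the amine nitrogen

This account rests on a few compounds, and the source may have more. Where it says the series, first, only, none or still open, it means among the compounds named here.

Measured compounds:
compound 1 `CC(=O)Nc1ccc([C@H](C)NCC2CCN(CCCc3c[nH]c4ccc(-n5cnnc5)cc34)CC2)cc1`, 99%
compound 2 `CC(=O)Nc1ccc(CNC2CCN(CCCc3c[nH]c4ccc(-n5cnnc5)cc34)CC2)cc1`, 75%
compound 3 `OC[C@H](NC1CCN(CCCc2c[nH]c3ccc(Cn4cncn4)cc23)CC1)c1ccccc1`, 76%

In a functional assay on CHO cells for activation of 5-hydroxytryptamine receptor 1D (Homo sapiens), read by GTPgammaS binding (on this read-out higher numbers stand for larger maximal responses and lower numbers for smaller maximal responses), compound 1 gives 99%, the highest of the three numbers. Compound 3 in this assay gives 76%, a number beyond the scatter below it, and compound 2 in this assay gives 75%, also beyond the scatter below it. Compound 4 `c1ccc2c(c1)CCC2NCC1CCN(CCCc2c[nH]c3ccc(-n4cnnc4)cc23)CC1` has not been measured. It differs from compound 1 in one place: 2,3-dihydro-1H-inden-1-yl in place of 1-(4-acetamidophenyl)ethyl on an amine nitrogen. Among the compounds with values here, no measured pair shows this change, so its effect is not known from the data. Since compound 2 and compound 3, which carry other groups on that amine nitrogen, each fall beyond the scatter below compound 1, a step downward of moderate size is expected in this assay. Compound 4 is therefore expected to give 80% (range 58% to 100%), a change of a number 19 percentage points lower from compound 1 to compound 4 (beyond the scatter).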

Compound 4, largest response reached (reported as efficacy), in percent of the reference or control that the assay uses: 78%
Compound 4: the middle estimate sits 2 percentage points above what was measured; low and high end bracket the measured number.
By their numbers in this assay, from the lowest: compounds 2, 3 and 4 (each within the scatter of the next); then compound 1.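

The first step read at this amine nitrogen is a number 21 percentage points lower from compound 1 to compound 4 (beyond the scatter) in this assay. Swapping 1-(4-acetamidophenyl)ethyl for 2,3-dihydro-1H-inden-1-yl therefore costs maximal response, while compound 4 still reaches 78% with 0 hydrogen-bond donors and 0 hydrogen-bond acceptors in the entering group. Nothing shown explains this step.

The compounds shown leave open whether the loss follows from removing the acetamido group or from closing the ring, which a plain 1-phenylethyl group on the same nitrogen would separate. Going by these compounds, the separate enantiomers of the 2,3-dihydro-1H-inden-1-yl compound also remain open.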